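The source may report more compounds than this note shows. Statements on the series, on what has been measured and on what is new or still open speak of the compounds shown alone.

Compound 1 `O=Cc1ccc(-c2cn3ccnc3c(-c3ccc4ncn(C5CCCCC5)c4c3)n2)cc1`: 37.8%
Compound 2 `Fc1ccc(-c2cn3ccnc3c(-c3ccc4ncn(C5CCCCC5)c4c3)n2)cc1`: 6.12%
Compound 3 `Clc1ccc(-c2cn3ccnc3c(-c3ccc4ncn(C5CCCCC5)c4c3)n2)cc1`: 4.14%

In a functional assay on NCI-H460 cells (Homo sapiens) for inhibition, read by sulforhodamine B assay, with a stated time of 48 h, tested at 10 uM (a lower number here means less inhibition, a higher number more inhibition at the concentration tested (going by the name of the read-out)), compound 3 gives the lowest of the three numbers. Its nearest neighbour is compound 2: a number 2 percentage points lower from compound 2 to compound 3 (within the scatter), a step within the scatter, so the two are not distinguishable here. The furthest is compound 1: a number 33.7 percentage points lower from compound 1 to compound 3 (beyond the scatter), a large step, and the companion change a number 31.7 percentage points lower from compound 1 to compound 2 (beyond the scatter) is of the same order.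

The next compound, compound 4 `Brc1ccc(-c2cn3ccnc3c(-c3ccc4ncn(C5CCCCC5)c4c3)n2)cc1`, differs from compound 3 in one place: bromo in place of chloro on an aromatic carbon.

Among the measured compounds shown here, the only measured step that bears directly on this change is the one from compound 2 to compound 3, where one such group replaced another on the same aromatic carbon and the read-out in this assay did not move beyond the scatter. The two large steps both involve loss of the formyl group and do not speak to this exchange. He therefore expects no step beyond the scatter: a number 0.9 percentage points higher from compound 3 to compound 4 (within the scatter) is the estimated change. Compound 4 is expected to give 5% in this assay, in the range 0% to 15%.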

Compound 4, a percentage reported as inhibition, at one concentration (the size of the read-out at that concentration, not a potency): 13.2%
Estimate against measurement, compound 4: 8.2 percentage points below; the range from low to high includes it.
By their numbers in this assay, from the lowest: compounds 3, 2 and 4 (each within the scatter of the next); then compound 1.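

With a number 9.1 percentage points higher from compound 3 to compound 4 (within the scatter) and a number 7.1 percentage points higher from compound 2 to compound 4 (within the scatter) in this assay, the series now holds fluoro, chloro and bromo on this aromatic carbon, para to a large group, and no exchange among the three leaves the scatter. Bromo also stays apart from formyl, with a number 24.6 percentage points lower from compound 1 to compound 4 (beyond the scatter) beyond the scatter, so the separation of compound 1 from compound 2 and compound 3 extends to compound 4, though this step is only modest. Nothing measured here explains why formyl stands apart from these three groups.

The compounds shown leave open whether another carbonyl group at this carbon, such as acetyl or a carboxylic acid, would stand with compound 1 or with the others. They also leave open where an amine at the same carbon would fall.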